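Stilbene extension on a phenol series: cytotoxicity in Raji cells

The source may hold more compounds than are shown below. What is called first, only, known or untested is meant among the compounds shown, and "the series" means these compounds.

Measured so far:
Compound 1 `C=C[C@@](C)(/C=C/c1ccc(O)cc1)CC/C=C/C(=O)OCc1ccccc1` gives > 26000 nM in a functional assay on Raji cells (Homo sapiens) for cytotoxicity, with a stated time of 72 h; a higher number here means that more compound is needed for the effect, a lower number that less compound is needed; this is a limit of the assay.
Compound 2 `C=C[C@@](C)(/C=C/c1ccc(O)c(C=O)c1)CCC=C(C)C` gives > 26000 nM in this assay; this too is a limit of the assay.

Compound 2 therefore stands at the limit of this assay and carries no number of its own. Compound 1 sits at the same limit, so neither value separates the two compounds or orders them, as the limit of > 26000 nM in this assay, at which 2 of the 2 values shown sit, shows: both results are limits and nothing else.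

Compound 3 `C=C[C@@](C)(/C=C/c1ccc(O)c(/C=C/c2ccc(Cl)cc2)c1)CCC=C(C)C` is the next compound to be measured in this assay. It differs from compound 2 in one place: 2-(4-chlorophenyl)ethenyl in place of formyl on an aromatic carbon.

Going by the values given here, no step between measured compounds is available, so the expected size of the change rests on the structural change alone. A modest gain in potency is expected, with the estimated step of an at least 1.7-fold lower number from compound 2 to compound 3 (0.23 log units; that floor lies within the scatter). For compound 3 the estimated value in this assay is 15000 nM, expected to lie between 3000 nM and 30000 nM, with a real chance that only a limit is again reported.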

Compound 3, half-maximal effective concentration: > 26000 nM
Compound 3: a limit, no number (the forecaster's own chance of this, stated with the estimate: 45%); middle value at least 1.7-fold (0.23 log units) away from the limit.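

No step can be read from compound 2 to compound 3, because both results in this assay are limits: the limit of > 26000 nM in this assay, at which 3 of the 3 values shown sit.

The compounds shown leave open whether 2-(4-chlorophenyl)ethenyl in place of formyl changes anything in this assay, and what value any member of the series would give there.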